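Swapping Nitro for Chloro on the Amide-Side Ring

The source may report more compounds than this note shows. Statements on the series, on what has been measured and on what is new or still open speak of the compounds shown alone.

Of the compounds shown here, three built on one shared core have been tested in a functional assay on HCT-116 cells (Homo sapiens) for inhibition, read by MTT assay, with a stated time of 72 h; a lower number here means a stronger inhibitor, a higher number a weaker inhibitor. Compound 1, `O=C(Nc1ccccc1[N+](=O)[O-])c1ccc(/N=N\c2c[nH]c3ccccc23)cc1`, gives 208000 nM in this assay. Compound 2, `O=C(Nc1ccccc1Cl)c1ccc(/N=N\c2c[nH]c3ccccc23)cc1`, gives 120000 nM. Compound 3, `O=C(Nc1ccc([N+](=O)[O-])cc1)c1ccc(/N=N\c2c[nH]c3ccccc23)cc1`, gives 156000 nM. All three numbers sit close together: a 1.7-fold lower number from compound 1 to compound 2 (0.24 log units; within the scatter), a 1.3-fold lower number from compound 1 to compound 3 (0.12 log units; within the scatter), and a 1.3-fold higher number from compound 2 to compound 3 (0.11 log units; within the scatter). The way compound 1 and compound 3 differ is counted in 4-nitrophenyl in place of 2-nitrophenyl on an amide-type nitrogen.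

Compound 4, `O=C(Nc1ccc(Cl)cc1)c1ccc(/N=N\c2c[nH]c3ccccc23)cc1`, has not yet been measured. It differs from compound 3 as counted in chloro in place of nitro on an aromatic carbon. The same exchange occurs once more among these compounds, between compound 1 and compound 2, counted in chloro in place of nitro on an aromatic carbon. The place is not identical: in compound 2 the chloro sits ortho to a large group, while in compound 4 it sits para to a large group, so this is the same kind of change rather than the same change. In this assay the earlier exchange gave a step that stayed within the usual scatter, a 1.7-fold lower number from compound 1 to compound 2 (0.24 log units; within the scatter). A step of about that size is expected for compound 4, a 1.6-fold lower number from compound 3 to compound 4 (0.19 log units; within the scatter), resting on that single earlier step. The number expected for compound 4 in this assay is 100000 nM, with a likely range from 50000 nM to 250000 nM.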

Compound 4, half-maximal inhibitory concentration: 187000 nM
The estimate for compound 4 lay 1.9-fold (0.27 log units) below the measured number; the range from low to high includes it.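

The exchange of nitro for chloro has now been read twice in this assay, with the rest of the molecule, here called the core, differing between the two readings, and the two readings cannot be told apart: the same change on two cores in this assay, a 1.7-fold lower number (0.24 log units; within the scatter) from compound 1 to compound 2 and a 1.2-fold higher number (0.08 log units; within the scatter) from compound 3 to compound 4, 2.1-fold (0.32 log units) apart, within the scatter of two such steps. The new step is a 1.2-fold higher number from compound 3 to compound 4 (0.08 log units; within the scatter), and compound 4 also adds a 1.6-fold higher number from compound 2 to compound 4 (0.19 log units; within the scatter) and a 1.1-fold lower number from compound 1 to compound 4 (0.05 log units; within the scatter), so every step that compound 4 adds lies within the usual scatter of repeated measurements. Among these compounds, this shows that, in these two pairs, the exchange gave no step large enough to read in either of the two settings, but it does not show that the exchange has no effect at all, that one step truly points the opposite way from the other, or that the result would hold on any other core.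

Nitro and chloro are the only groups exchanged here, so it remains open whether an amine or a carboxylic acid at the same place would give a step beyond the scatter. Whether the two steps would still agree once a step large enough to read appears also stays unanswered, and two pairs are too few to settle it.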